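This account rests on a few compounds, and the source may have more. Where it says the series, first, only, none or still open, it means among the compounds named here.

Three compounds share one core, an amide joined to a pyridine ring and to a benzene ring that carries a benzyl-type ether. Compound 1 `O=C(Nc1ccccn1)c1ccccc1OCc1ccccc1` is measured in an assay on lysate for inhibition of phosphatidylcholine:ceramide cholinephosphotransferase 2 (Homo sapiens), read by HPLC, with stated times of 30 min and 2 h (a lower number here means a stronger inhibitor, a higher number a weaker inhibitor), at 11700 nM. Compound 2 `O=C(Nc1cccnc1)c1ccccc1OCc1ccccc1` gives 3200 nM in this assay, and compound 3 `O=C(Nc1cccnc1)c1ccccc1OCc1cccc(Cl)c1` gives 1400 nM. Among these three numbers compound 2 stands second highest: one step, a 3.7-fold lower number from compound 1 to compound 2 (0.56 log units; beyond the scatter), lies on one side of it, and another, a 2.3-fold lower number from compound 2 to compound 3 (0.36 log units; beyond the scatter), on the other.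

Compound 4 `O=C(Nc1cccnc1)c1ccccc1OCc1cc(F)ccc1Cl` has not yet been measured. It differs from compound 2 in one place (2-chloro-5-fluorophenyl in place of phenyl on a saturated chain carbon bound to an oxygen on an aromatic ring), so the ring at the end of the ether now carries both a chlorine and a fluorine instead of hydrogen only.

Going by the values given here, only the step of a 2.3-fold lower number from compound 2 to compound 3 (0.36 log units; beyond the scatter) bears on this change, since it also swaps a hydrogen on that ring for a chlorine, though at a different carbon. That step was modest but beyond the scatter. A halogen pair on the same ring is expected to lower the number by a similar modest amount, though the new positions leave room for doubt. Compound 4 is therefore expected to reach about 1500 nM in this assay, within 600 nM to 4000 nM, a step of a 2.1-fold lower number from compound 2 to compound 4 (0.33 log units; beyond the scatter) that is expected to stay modest.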

Compound 4, half-maximal inhibitory concentration: 740 nM
For compound 4 the middle estimate is 2.0-fold (0.31 log units) above the measured one; the range from low to high includes it.
By their numbers in this assay, from the lowest: compounds 4 and 3 (each within the scatter of the next); then compound 2; then compound 1.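

Going by these compounds alone, replacing phenyl with 2-chloro-5-fluorophenyl at this position in this assay gives a 4.3-fold lower number from compound 2 to compound 4 (0.64 log units; beyond the scatter), so a second halogen-bearing ring, with a different pattern from the one in compound 3, also lowers the number relative to the bare phenyl. The two halogenated rings cannot be told apart, however: a 1.9-fold lower number from compound 3 to compound 4 (0.28 log units; within the scatter), so carrying a fluorine as well as a chlorine, with the chlorine at a different carbon, shows no gain over 3-chlorophenyl. Nothing available explains why either halogenated ring gives a lower number than phenyl.

Compound 4 differs from compound 2 by both a chlorine and a fluorine, so the compounds shown leave open how much of that step belongs to each halogen, and whether 2-chlorophenyl or 3-fluorophenyl alone would give a similar number. They also leave open whether a group other than a halogen on this ring, such as a methoxy group or a nitrile, would lower the number as well, and whether 2-chloro-5-fluorophenyl would do the same on the pyridin-2-yl amide of compound 1.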